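A Hydroxymethyl Group Replaces a Sulfur-Bearing Side Group

A few compounds are considered here, and "the series" means these few. Any claim that something is new, unique, unknown or untested is made for them only; others in the source may bear on it.

In a functional assay on MDA-MB-231 cells (Homo sapiens) for cytotoxicity, read by MTT assay, with a stated time of 72 h (a lower number here means that less compound is needed, a higher number that more compound is needed for the effect), compound 1 (`CCCOC(=O)c1c(C)coc1-c1ccc2c(CC)cccc2c1OC`) gives > 10 ug/mL, which is a limit and not a number. Among the compounds with values here, compound 2 (`CCc1cccc2c(OC)c(-c3occ(C)c3C(=S)OC)ccc12`) gives 5.8 ug/mL, the only actual number so far. Compound 3 (`CCc1cccc2c(OC)c(-c3occ(C)c3CO)ccc12`) differs from it by one change: a group of 2 heavy atoms (1 carbon, 1 oxygen; no ring) in place of a group of 4 heavy atoms (2 carbon, 1 oxygen, 1 sulfur; no ring), on an aromatic carbon. Within the data shown here, the single measured step that bears on this, an at least 1.7-fold lower number from compound 1 to compound 2 (0.23 log units; that floor lies within the scatter), also concerns a group on an aromatic carbon, but it is only a floor within the scatter and sets no firm direction. The expected change, a 1.2-fold higher number from compound 2 to compound 3 (0.08 log units; within the scatter), therefore stays within the scatter. Compound 3 is estimated at 7 ug/mL, with an expected range of 3 ug/mL to 15 ug/mL.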

Compound 3, concentration for half-maximal effect: > 10 ug/mL
Compound 3: only a limit was reported; the forecaster's own chance of this, stated with the estimate: 35%; middle value at least 1.4-fold (0.15 log units) from the limit.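

At this place on the five-membered aromatic ring, hydroxymethyl in place of the sulfur-bearing group gives, in this assay, an at least 1.7-fold higher number from compound 2 to compound 3 (0.23 log units; that floor lies within the scatter). Within the data shown here, this is the first step at this position that starts from an actual number, yet its floor lies within the scatter and sets no firm direction. The step between compound 1 and compound 3 cannot be read, and the limit recurs: the limit of > 10 ug/mL in this assay, at which 2 of the 3 values shown sit.

On these data alone, it remains open what actual number compound 3 would give. As far as these compounds go, it also remains open whether an amine or a carboxylic acid on this aromatic carbon would give a number rather than a limit.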